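The source may hold more compounds than are shown below. What is called first, only, known or untested is meant among the compounds shown, and "the series" means these compounds.

Three compounds share one core and differ only in the aromatic group attached to a carbonyl carbon. Compound 1 `CC1(C)CC12NC(=O)N(NC(=O)c1ccc(Cl)cc1)C2=O` carries a 4-chlorophenyl group there, and in a functional assay on the whole organism (Hindlimb) for inhibition, with Mus musculus as the target, with a stated time of 4 h (on this read-out lower numbers stand for an effect already at smaller amounts and higher numbers for an effect only at larger amounts of compound), compound 1 gives 300 mg/kg. Compound 2 `CC1(C)CC12NC(=O)N(NC(=O)c1cccs1)C2=O` carries a thiophen-2-yl group instead, and in this assay compound 2 gives 300 mg/kg. Going by the values given here, the step of no change at the digits printed from compound 1 to compound 2 (within the scatter) shows that swapping one aromatic group for another at this carbonyl carbon left the dose unchanged within the usual scatter, so compound 2 stands level with compound 1 on the numbers known so far.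

Compound 3 `CC1(C)CC12NC(=O)N(NC(=O)c1ccncc1)C2=O` is not yet measured. It differs from compound 2 as follows: pyridin-4-yl in place of thiophen-2-yl on a carbonyl carbon. Among the compounds with values here, the only measured step that bears on this change is the one from compound 1 to compound 2, which replaced one aromatic group by another at the same carbonyl carbon and moved the dose by nothing beyond the scatter. On that basis the step of no change at the digits printed from compound 2 to compound 3 (within the scatter) is expected to fall within the scatter as well, in no clear direction. In this assay compound 3 is therefore estimated at 300 mg/kg, with a range from 150 mg/kg to 600 mg/kg.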

Compound 3, minimum effective dose: 300 mg/kg
The estimate for compound 3 equals the measured number at the digits printed; measured number inside the range.
By their numbers in this assay, from the lowest: compounds 1, 2 and 3 (each within the scatter of the next).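

Replacing the five-membered aromatic ring of thiophen-2-yl with the six-membered aromatic ring of pyridin-4-yl on this carbonyl carbon gives no change at the digits printed from compound 2 to compound 3 (within the scatter) in this assay and thus shows that a change of ring size and of hetero atom, from sulfur to nitrogen, leaves the minimum effective dose where it was. The comparison with the first aromatic group reads the same, with no change at the digits printed from compound 1 to compound 3 (within the scatter) for pyridin-4-yl in place of 4-chlorophenyl, so the three aromatic groups tried at this position cannot be told apart on this read-out, whether the ring is a benzene ring bearing chlorine, a thiophene or a pyridine. No accompanying measurement explains why these three groups give the same dose.

From the compounds shown here alone, whether the dose would respond to something other than an aromatic ring on this carbonyl carbon, such as an amine, a carboxylic acid or a longer alkyl chain, remains open. Also open, going by these compounds, is whether pyridin-2-yl or pyridin-3-yl, with the ring nitrogen placed differently, would match pyridin-4-yl.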